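A dichlorophenyl swap at the assay's limit

A few compounds are considered here, and "the series" means these few. Any claim that something is new, unique, unknown or untested is made for them only; others in the source may bear on it.

Measured in a functional assay on SK-MEL-2 cells (Homo sapiens) for inhibition, read by sulforhodamine B assay, with a stated time of 48 h; a higher number here means a weaker inhibitor of growth, a lower number a stronger inhibitor of growth:
- Compound 1 `O=C(Cc1csc2nc(-c3ccc(Br)cc3)cn12)N/N=C/c1ccccc1` gives > 100000 nM, a limit
- Compound 2 `O=C(Cc1csc2nc(-c3ccc(Br)cc3)cn12)N/N=C/c1ccccc1O` gives 53700 nM
- Compound 3 `COc1cccc(OC)c1/C=N/NC(=O)Cc1csc2nc(-c3ccc(Br)cc3)cn12` gives > 100000 nM, a limit

Compound 3 stands at the limit of > 100000 nM in this assay, at which 2 of the 3 values shown sit, so it has a limit and no number. Compound 4 `O=C(Cc1csc2nc(-c3ccc(Br)cc3)cn12)N/N=C/c1ccc(Cl)cc1Cl` has 2,4-dichlorophenyl in place of 2,6-dimethoxyphenyl on a carbon with a double bond to nitrogen.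

Going by the values given here, three measured steps bear on this same part of the molecule. The first shows an at least 1.8-fold lower number from compound 1 to compound 2 (0.27 log units; that floor lies within the scatter), the second shows an at least 1.8-fold higher number from compound 2 to compound 3 (0.27 log units; that floor lies within the scatter), and the third shows a step that the two limits leave unreadable from compound 1 to compound 3. None of them is shown to reach beyond the scatter, and none of them involves chlorine, so they give no firm size for this change. Among the compounds with values here, compound 2 , at 53700 nM, is the only compound here with a real number. That number lies not far from the limit that holds the other two compounds. Only a small move toward a lower number is therefore expected, and compound 4 may well end at the limit again. The expected step is an at least 1.4-fold lower number from compound 3 to compound 4 (0.15 log units; that floor lies within the scatter). For compound 4 the estimated value is 70000 nM, with an expected range from 25000 nM to 100000 nM.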

Compound 4, concentration for total growth inhibition: > 100000 nM
Compound 4: only a limit was reported (the forecaster's own chance of this, stated with the estimate: 55%); middle value at least 1.4-fold (0.15 log units) away from the limit.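

In this assay, going by these compounds alone, compound 4 has only a limit, so 2,4-dichlorophenyl, the only chlorine-bearing group at this place, yields no number: the limit of > 100000 nM in this assay, at which 3 of the 4 values shown sit. The one readable comparison is an at least 1.8-fold higher number from compound 2 to compound 4 (0.27 log units; that floor lies within the scatter), which does not separate the two compounds firmly, while the steps to compound 4 from compound 1 and from compound 3 join two limits and cannot be read. Within the data shown here, replacing 2,6-dimethoxyphenyl with 2,4-dichlorophenyl therefore shows no readable change, and 2-hydroxyphenyl in compound 2 remains the only group here that gives a real number.

The compounds shown leave open how the three compounds at the limit rank among themselves, and whether the hydroxy group truly matters, as the floor of an at least 1.8-fold lower number from compound 1 to compound 2 (0.27 log units; that floor lies within the scatter) does not clear the usual scatter. As far as these compounds go, it also remains open whether an amine or a carboxylic acid on this aromatic ring, or a longer chain in place of the ring, would bring a clear number in this assay.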